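The source may hold more compounds than are shown below. What is called first, only, known or untested is meant among the compounds shown, and "the series" means these compounds.

In a functional assay for antiproliferative activity, with Homo sapiens as the target (on this read-out lower numbers stand for stronger inhibition and higher numbers for weaker inhibition), the measured compounds stand as follows.
Compound 1 `CNC(=O)OCc1c2c(n(C)c1COC(C)=O)C(=O)C(C)=C(OC)C2=O` gives 0.09 ug/mL.
Compound 2 `CNC(=O)OCc1c2c(n(C)c1COC(=O)NC)C(=O)C(C)=C(OC)C2=O` gives < 0.03 ug/mL, which is a limit of the assay rather than a number (the limit of < 0.03 ug/mL in this assay, at which 1 of the 3 values shown sits).
Compound 3 `CNC(=O)OCc1c2c(n(C)c1COC(C)=O)C(O)=C(C)C(=N)C2=O` gives 12.8 ug/mL.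

Compound 3 holds the highest of the two numbers; its nearest neighbour, compound 1, shows a much lower one. Compound 4 `CNC(=O)OCc1c2c(n(C)c1COC(=O)NC)C(O)=C(C)C(=N)C2=O` differs from compound 3 by methylamino in place of methyl on a carbonyl carbon. Within the data shown here, the one measured step of this kind is an at least 3.0-fold lower number from compound 1 to compound 2 (0.47 log units; beyond the scatter). Compound 4 is therefore expected to move in the same direction in this assay, with a step of about a 3.2-fold lower number from compound 3 to compound 4 (0.51 log units; beyond the scatter). The value of compound 4 is estimated at 4 ug/mL, within a range from 1 ug/mL to 15 ug/mL.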

Compound 4, half-maximal inhibitory concentration: 3.1 ug/mL
Beside the measured number, compound 4's estimate is 1.3-fold (0.11 log units) above it; the range from low to high includes it.
By their numbers in this assay, from the lowest: compound 1; then compound 4; then compound 3. At a limit, below all of these: compound 2.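

In this assay, the change from acetoxy to (methylcarbamoyl)oxy now has a step with a number at both ends: a 4.1-fold lower number from compound 3 to compound 4 (0.62 log units; beyond the scatter). The lower number thus appears on two cores, not one, though the sizes cannot be set against each other: the same change on two cores in this assay, an at least 3.0-fold lower number (0.47 log units; beyond the scatter) from compound 1 to compound 2 and a 4.1-fold lower number (0.62 log units; beyond the scatter) from compound 3 to compound 4; the limit leaves it open whether they differ

The compounds shown leave open whether ethylamino or plain amino, in the same place on a carbonyl carbon, would go the same way as methylamino. From the compounds shown here alone, compound 2 gives < 0.03 ug/mL, which is a limit of the assay, so the size of the step on its core also stays open.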